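This account rests on a few compounds, and the source may have more. Where it says the series, first, only, none or still open, it means among the compounds named here.

Measured compounds:
compound 1 `O=C(c1ccc(CN2C(=O)c3ccccc3S2(=O)=O)cc1)N1CCCCC1` — 69200 nM
compound 2 `CC(C)(C)OC(=O)N(Cc1ccco1)C(=O)c1ccc(CN2C(=O)c3ccccc3C2=O)cc1` — > 100000 nM

Going by the values given here, in an ADME assay on RAW264.7 cells (Mus musculus) for cytotoxicity, read by WST assay (on this read-out lower numbers stand for higher toxicity in this test and higher numbers for lower toxicity in this test), compound 1 gives 69200 nM, the only numerical value among the two results. Compound 2 `CC(C)(C)OC(=O)N(Cc1ccco1)C(=O)c1ccc(CN2C(=O)c3ccccc3C2=O)cc1` reaches only a limit of the assay, > 100000 nM. That leaves compound 1 as the sole fixed point, with the limit of > 100000 nM in this assay, at which 1 of the 2 values shown sits, marking where the other result sits. Compound 3 `CN(Cc1ccco1)C(=O)c1ccc(CN2C(=O)c3ccccc3S2(=O)=O)cc1` is the next to be measured in this assay. It differs from compound 1 by ((furan-2-yl)methyl)(methyl)amino in place of piperidin-1-yl on a carbonyl carbon. Among the compounds with values here, no measured pair shows the effect of such a change, so compound 1 alone carries the forecast. The step from compound 1 to compound 3 is expected to be a 1.2-fold higher number from compound 1 to compound 3 (0.06 log units; within the scatter), which would fall within the usual scatter. Compound 3 is therefore estimated at 80000 nM in this assay, with a range from 30000 nM to 200000 nM, and a fair chance that only a limit is returned.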

Compound 3, concentration lethal to 50% of the cells: > 100000 nM
Compound 3: a limit, no number (the forecaster's own chance of this, stated with the estimate: 40%); middle value at least 1.2-fold (0.09 log units) from the limit.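

In this assay, compound 3 returns only a limit, as compound 2 does: the limit of > 100000 nM in this assay, at which 2 of the 3 values shown sit.

Going by these compounds alone, putting ((furan-2-yl)methyl)(methyl)amino in place of piperidin-1-yl on the carbonyl carbon gives the first step that can be read at this position, an at least 1.4-fold higher number from compound 1 to compound 3 (0.15 log units; that floor lies within the scatter). From the compounds shown here alone, the change therefore does not bring the number down on the core of compound 1, but the true size of the step remains unknown, and its floor alone does not separate the two compounds.

The compounds shown leave open whether the furan ring or the methyl on the amide nitrogen matters more in this change. They also leave open whether a morpholin-4-yl or a dimethylamino group at this position would stay at the limit or give a number.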